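Acetamido for Acetoxy on the Coumarin Migration Series

A few compounds are considered here, and "the series" means these few. Any claim that something is new, unique, unknown or untested is made for them only; others in the source may bear on it.

Compound 1 `CC(=O)OCc1ccc2oc(=O)c(C(=O)Oc3cccc(Cl)c3)cc2c1`: 49.1%
Compound 2 `CC(=O)OCc1ccc2oc(=O)c(C(=O)Sc3cccc(Br)c3)cc2c1`: 70.9%

In a functional assay on HT-1080 cells (Homo sapiens), read by transwell migration, with a stated time of 24 h, tested at 1 uM (a lower number here means a stronger effect, a higher number a weaker effect of the compound at the concentration tested), compound 1 gives 49.1%, the lowest of the two numbers; compound 2 is nearest, with a number 21.8 percentage points higher from compound 1 to compound 2 (beyond the scatter). Compound 3 `CC(=O)NCc1ccc2oc(=O)c(C(=O)Oc3cccc(Cl)c3)cc2c1` differs from compound 1 by acetamido in place of acetoxy on a saturated chain carbon bound to an aromatic carbon. Among the compounds with values here, the only measured step changes the ester side of the molecule, not the chain carbon bound to the aromatic carbon, so no step bears directly on this change. With nothing in the numbers pointing one way, a step within the scatter is expected, a number 5.9 percentage points higher from compound 1 to compound 3 (within the scatter). Compound 3 is therefore estimated at 55%, in the range 35% to 75%.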

Compound 3, a percentage reported as activity, at one concentration (the size of the read-out at that concentration, not a potency): 36.6%
The estimate for compound 3 lay 18.4 percentage points above the measured number; the measured number falls inside the stated range.
By their numbers in this assay, from the lowest: compound 3; then compound 1; then compound 2.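

In this assay, acetamido in place of acetoxy gives a number 12.5 percentage points lower from compound 1 to compound 3 (beyond the scatter), so the saturated chain carbon bound to an aromatic carbon, untouched in the earlier pair, does bear on the read-out. Acetoxy is therefore not needed for the effect seen with compound 1, and the lower number marks a stronger effect at the concentration tested. Nothing measured here accounts for this step. Still open, from the compounds shown here alone, is how a free amine or a longer propionamido chain on this carbon would read, and whether acetamido gives a similar step alongside the (3-bromophenyl)sulfanyl group of compound 2.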